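Three ethers of one isoflavone core, and an allyl ether

The source may hold more compounds than are shown below. What is called first, only, known or untested is meant among the compounds shown, and "the series" means these compounds.

Measured in a functional assay on mitochondria (Cricetulus griseus) for inhibition of Monoamine oxidase (Homo sapiens), tested at 9 uM; on this read-out higher numbers stand for a stronger effect at the one concentration tested and lower numbers for a weaker effect:
compound 1 `O=c1c(-c2ccc(O)cc2)coc2cc(OCCCBr)ccc12`: 100%
compound 2 `O=c1c(-c2ccc(O)cc2)coc2cc(OCC(O)CO)ccc12`: 95.1%
compound 3 `O=c1c(-c2ccc(O)cc2)coc2cc(OCCC3OCCCO3)ccc12`: 88.5%

Compound 2 sits in the middle of the three numbers, and both of its neighbours lie within the scatter of it: the step of a number 4.9 percentage points lower from compound 1 to compound 2 (within the scatter) and the step of a number 6.6 percentage points lower from compound 2 to compound 3 (within the scatter) are each too small to count as a real difference. Among the measured compounds shown here, only the step of a number 11.5 percentage points lower from compound 1 to compound 3 (beyond the scatter) reaches beyond the scatter, and then only modestly.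

Compound 4 `C=CCOc1ccc2c(=O)c(-c3ccc(O)cc3)coc2c1` has not been measured. Its difference from compound 2 is vinyl in place of 1,2-dihydroxyethyl on a saturated chain carbon bound to an oxygen on an aromatic ring. For the measured compounds named here, both measured steps that touch the same saturated chain carbon bound to an oxygen on an aromatic ring, the one from compound 1 to compound 2 and the one from compound 2 to compound 3, stayed within the scatter, and even the one step beyond the scatter was modest. Every change of the side chain so far has left the read-out near the top of the scale. The expected step is therefore a number 1.1 percentage points lower from compound 2 to compound 4 (within the scatter), that is, no move beyond the scatter in either direction.

For compound 4 the estimate is 94%, with a range from 84% to 100%.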

Compound 4, a percentage reported as inhibition, at one concentration (the size of the read-out at that concentration, not a potency): 100%
Compound 4: middle estimate off by 6 percentage points, on the low side, and the stated range covers the measured number.
By their numbers in this assay, from the lowest: compounds 3, 2, 1 and 4 (each within the scatter of the next, the first and the last beyond it).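

Replacing 1,2-dihydroxyethyl with vinyl on a saturated chain carbon bound to an oxygen on an aromatic ring removes all the hydrogen-bond donors and acceptors of the leaving group, yet in this assay it gives a number 4.9 percentage points higher from compound 2 to compound 4 (within the scatter), so the diol is not needed to keep the read-out near the top of the scale. Neither is the bromine, for vinyl in place of 2-bromoethyl gives no change at the digits printed from compound 1 to compound 4 (within the scatter). Among the compounds shown here, the one new step beyond the scatter is the modest a number 11.5 percentage points higher from compound 3 to compound 4 (beyond the scatter), which leaves compound 3, with its six-membered ring, apart from compound 1 and compound 4 but not from compound 2.

Nothing available explains any of these steps. On these data alone, with compound 1 at 100% and compound 4 at 100% at a single concentration, this assay cannot show whether the two differ in potency, and it remains open whether a chain ending in an amine or a carboxylic acid at this position would lower the read-out.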